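Swapping Chlorine for Methyl on the Outer Ring

The source may hold more compounds than are shown below. What is called first, only, known or untested is meant among the compounds shown, and "the series" means these compounds.

Compound 1, `COC(=O)/C=C/c1cccc(N(Cc2ccc(/C=C/c3cccc(C(F)(F)F)c3)cc2)C(=O)C(C)C)c1`: 267 nM
Compound 2, `COC(=O)/C=C/c1cccc(N(Cc2ccc(/C=C/c3c(C)cc(C)cc3C)cc2)C(=O)C(C)C)c1`: 149 nM
Compound 3, `COC(=O)/C=C/c1cccc(N(Cc2ccc(-c3cccc(Cl)c3)cc2)C(=O)C(C)C)c1`: 77 nM

All three were measured in an assay on isolated protein with Bile acid receptor (Homo sapiens) as the target; on this read-out higher numbers stand for an effect only at larger amounts of compound and lower numbers for an effect already at smaller amounts. Compound 3 shows the lowest of the three numbers, but only its distance to compound 1 lies beyond the scatter, while its distance to compound 2 lies within it. Compound 4, `COC(=O)/C=C/c1cccc(N(Cc2ccc(-c3ccc(C)cc3)cc2)C(=O)C(C)C)c1`, differs from compound 3 by 4-methylphenyl in place of 3-chlorophenyl on an aromatic carbon. The measured steps of a 3.5-fold lower number from compound 1 to compound 3 (0.54 log units; beyond the scatter) and a 1.9-fold lower number from compound 2 to compound 3 (0.29 log units; within the scatter) both concern a different change, the replacement of an ethenyl-linked ring by a ring bound directly, and say nothing about exchanging a chlorine for a methyl. Among the compounds with values here, with no step of this kind on record, the expectation is no shift beyond the scatter, an estimated 1.3-fold higher number from compound 3 to compound 4 (0.11 log units; within the scatter). For compound 4 the estimate in this assay is 100 nM, ranging from 35 nM to 300 nM.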

Compound 4, half-maximal effective concentration: 118 nM
For compound 4 the middle estimate is 1.2-fold (0.07 log units) below the measured one; the range from low to high includes it.
By their numbers in this assay, from the lowest: compounds 3, 4, 2 and 1 (each within the scatter of the next, the first and the last beyond it).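

In this assay, the exchange gives a 1.5-fold higher number from compound 3 to compound 4 (0.19 log units; within the scatter), so 3-chlorophenyl and 4-methylphenyl cannot be told apart here, even though both the substituent and its place on the ring differ. With a methyl-bearing ring bound directly, the result is a 1.3-fold lower number from compound 2 to compound 4 (0.10 log units; within the scatter), also within the scatter, and a 2.3-fold lower number from compound 1 to compound 4 (0.35 log units; beyond the scatter), beyond it, the same pattern that compound 3 showed. No measurement available explains these differences. The effects of the substituent and of its place remain tangled, and 3-methylphenyl or 4-chlorophenyl would separate them. As far as these compounds go, how a ring carrying an amine or a carboxylic acid would read is also open.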